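A few compounds are considered here, and "the series" means these few. Any claim that something is new, unique, unknown or untested is made for them only; others in the source may bear on it.

Measured in an assay on cells for inhibition of mitogen-activated protein kinase kinase kinase 20 (Homo sapiens), read by ADP-Glo, with a stated time of 30 min; a higher number here means a weaker inhibitor, a lower number a stronger inhibitor:

compound 1 `COc1n[nH]c2ncc(C#Cc3c(F)ccc(NS(=O)(=O)c4cccc(Cl)c4)c3F)cc12`: 4.2 nM
compound 2 `COc1n[nH]c2ncc(C#Cc3c(F)ccc(NS(=O)(=O)c4cccc(Cl)c4Cl)c3F)cc12`: 9.6 nM
compound 3 `O=S(=O)(Nc1ccc(F)c(C#Cc2ccc3[nH]ncc3c2)c1F)c1cccc(Cl)c1`: 994 nM

Compound 3 stands at the highest of the three numbers in this assay; compound 2 sits at 9.6 nM and compound 1 at 4.2 nM, both gaps beyond the scatter, so compound 3 is the weakest inhibitor of the three.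

Compound 4 `O=S(=O)(Nc1ccc(F)c(C#Cc2cnc3[nH]ncc3c2)c1F)c1cccc(Cl)c1` differs from compound 3 in one place: a group of 9 heavy atoms (6 carbon, 3 nitrogen; one five-membered aromatic ring with 2 hetero atoms, one six-membered aromatic ring with 1 hetero atom) in place of a group of 9 heavy atoms (7 carbon, 2 nitrogen; one five-membered aromatic ring with 2 hetero atoms, one six-membered aromatic ring of carbon only), on a triple-bonded carbon. Within the data shown here, the only measured single-point step, a 2.3-fold higher number from compound 1 to compound 2 (0.36 log units; beyond the scatter), concerns a chloro on the sulfonyl-bearing ring and does not bear on this change. Compounds 1 and 2 both carry the six-membered aromatic ring with one hetero atom that enters here, but each also carries a methoxy group on the five-membered ring, so their low numbers against compound 3 show two changes at once and cannot be split. The direction is therefore expected to be downward, toward the numbers of compound 1 and compound 2, but the size cannot be read from a clean pair.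

The estimate for compound 4 in this assay is 150 nM, range 30 nM to 700 nM, a step of a 6.6-fold lower number from compound 3 to compound 4 (0.82 log units; beyond the scatter) expected.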

Compound 4, half-maximal inhibitory concentration: 5.1 nM
For compound 4 the middle estimate is 29-fold (1.47 log units) above the measured one; measured number below the stated range.
By their numbers in this assay, from the lowest: compounds 1, 4 and 2 (each within the scatter of the next, the first and the last beyond it); then compound 3.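

In this assay, the swap on the triple-bonded carbon, from 1H-indazol-5-yl to the group whose six-membered aromatic ring carries one hetero atom, gives on its own a 190-fold lower number from compound 3 to compound 4 (2.29 log units; beyond the scatter), with the rest of the molecule unchanged. The methoxy group is now separated from that swap: hydrogen in its place gives a 1.2-fold higher number from compound 1 to compound 4 (0.08 log units; within the scatter), so the low numbers of compound 1 and compound 4 do not depend on methoxy in this assay, and the large step belongs to the ring change. No independent data on these compounds account for the size of the step, so it stands as an observation without a stated cause.

From the compounds shown here alone, whether methoxy is equally without consequence on the carbon-only ring of compound 3 remains open, since the step from compound 1 to compound 4 was read only with the ring that carries the hetero atom. Also open, going by these compounds, is how larger or different groups in the place of that methoxy, such as an amine or a longer alkoxy chain, would fare, and whether the chloro step from compound 1 to compound 2 carries over to compound 4.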